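Swapping Allyl for Phenyl on a Shared Core

The compounds below may be only part of what the source reports. "The series", "measured", "known", "first", "only" and "open" are said of these compounds alone.

Of the compounds shown here, three have so far been tested in an ADME assay on TERT-RPE1 cells (Homo sapiens) for cytotoxicity, read by resazurin assay, with a stated time of 48 h; on this read-out lower numbers stand for stronger inhibition and higher numbers for weaker inhibition. Compound 1 `CCOc1ccc(NC(=O)c2c(N)n[nH]c2Nc2ccccc2)cc1` gives 67800 nM in this assay. Compound 2 `C=CCNc1[nH]nc2nnn(-c3ccc(OCC)cc3)c(=O)c12` gives only a limit of the assay in this assay, > 100000 nM. Compound 3 `CCOc1ccc(NC(=O)/C(C#N)=C(\NC)SC)cc1` likewise gives only a limit in this assay, > 100000 nM. Two of the three results sit at the limit of > 100000 nM in this assay, at which 2 of the 3 values shown sit, and compound 2 is one of them, so its place on the scale is known only as a limit and not as a number.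

Compound 4 `CCOc1ccc(-n2nnc3n[nH]c(Nc4ccccc4)c3c2=O)cc1` differs from compound 2 in one place: phenyl in place of allyl on a nitrogen on an aromatic ring. Within the data shown here, no pair of measured compounds differing in a single place is available, so no measured step shows how large such a change can be here. With compound 2 known only as > 100000 nM, the expected step of a number no higher from compound 2 to compound 4 (the limit leaves the size open) is none beyond the scatter. Compound 4 is therefore estimated at about 100000 nM, between 40000 nM and 300000 nM, and will most likely again be reported as a limit rather than a number.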

Compound 4, half-maximal inhibitory concentration: > 100000 nM
Compound 4: no number, only a limit; the forecaster's own chance of this, stated with the estimate: 70%; the middle value sits exactly at the limit.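

Among these compounds, compound 2 and compound 4 both give only a limit in this assay, so no step between them can be read. The compounds shown leave open what number either compound would have, and so whether phenyl in place of allyl changes the read-out at all.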